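Stripping the Amino Group from Compound 1

A few compounds are considered here, and "the series" means these few. Any claim that something is new, unique, unknown or untested is made for them only; others in the source may bear on it.

Going by the values given here, in an assay on isolated protein for inhibition of ribosomal protein S6 kinase alpha-1 (Homo sapiens), read by mobility shift assay, tested at 30 uM (on this read-out lower numbers stand for less inhibition and higher numbers for more inhibition at the one concentration tested (going by the name of the read-out)), compound 1 `Cc1cc2[nH]nc(N)c2c(=O)[nH]1` gives 6%, the lowest of the three numbers measured so far. Compound 2 `Nc1n[nH]c2cc(-c3cccs3)[nH]c(=O)c12` gives 35%, and compound 3 `Nc1n[nH]c2cc(CC3CCNCC3)[nH]c(=O)c12` gives 11%. The step of a number 29 percentage points higher from compound 1 to compound 2 (beyond the scatter) is modest but lies beyond the scatter, whereas the step of a number 5 percentage points higher from compound 1 to compound 3 (within the scatter) lies within the scatter, so compound 1 and compound 3 cannot be told apart on this read-out.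

Compound 4 `Cc1cc2[nH]ncc2c(=O)[nH]1` differs from compound 1 at another place: hydrogen in place of amino on an aromatic carbon. Neither measured step touches the amino group; both alter a different substituent on the shared core, so they give no direct guide to this change. What they do show is that compound 1 sits close to the floor of the read-out, leaving little room for a lower number. Among the compounds with values here, with no bearing step available, the expectation for compound 4 is of no change beyond the scatter, and the estimated step of a number 2 percentage points lower from compound 1 to compound 4 (within the scatter) expresses exactly that. Compound 4 is therefore estimated at 4% in this assay, within a range from -6% to 16%.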

Compound 4, a percentage reported as inhibition, at one concentration (the size of the read-out at that concentration, not a potency): -3%
Compound 4: middle estimate off by 7 percentage points, on the high side, and the stated range covers the measured number.
By their numbers in this assay, from the lowest: compounds 4, 1 and 3 (each within the scatter of the next, the first and the last beyond it); then compound 2.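

In this assay, hydrogen in place of amino on an aromatic carbon of the five-membered aromatic ring gives a number 9 percentage points lower from compound 1 to compound 4 (within the scatter), so with methyl on the shared core, compound 1 and compound 4 cannot be told apart on this read-out. Going by these compounds alone, this is the first direct reading at this position, and it shows no loss or gain beyond the scatter when the amino group goes. Both compounds lie at the low end of the numbers shown, however, so the pair shows little about what the amino group does in a compound with more inhibition to lose, and nothing measured here explains the result.

The compounds shown leave open whether hydrogen in place of amino would read the same way alongside the thiophen-2-yl group of compound 2, which gives 35%. They also leave open how a larger group at this position, such as a methylamino group or a carboxylic acid, would read on the same core.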